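Swapping the Aryl Group on the Cyclopropane of Compound 3

The source may hold more compounds than are shown below. What is called first, only, known or untested is meant among the compounds shown, and "the series" means these compounds.

This set of four compounds shares one core and was characterised in a functional assay for agonist activity at G protein-coupled receptor 88 (Homo sapiens), read by HTRF and cAMP accumulation; on this read-out lower numbers stand for an effect already at smaller amounts and higher numbers for an effect only at larger amounts of compound. Among the measured compounds shown here, compound 1 `NC1(CN(C(=O)[C@@H]2C[C@H]2c2ccccc2)c2ccc(-c3ccccc3)cc2)CCCC1` gives 0.57 nM, and compound 2 `CC(C)CCNCCN(C(=O)[C@@H]1C[C@H]1c1ccccc1)c1ccc(-c2ccccc2)cc1` gives 5.1 nM; the only single-point step among the measured compounds, an 8.9-fold higher number from compound 1 to compound 2 (0.95 log units; beyond the scatter), concerns the chain that carries the amine and not the aryl group on the three-membered ring. Compound 3 `CC[C@H](C)[C@H](N)CN(C(=O)[C@@H]1C[C@H]1c1cc(F)ccc1F)c1ccc(-c2ccccc2)cc1` gives 770 nM, the highest of the three numbers, with compound 2 nearest and compound 1 furthest, both gaps beyond the scatter.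

Compound 4 `CC[C@H](C)[C@H](N)CN(C(=O)[C@@H]1C[C@H]1c1csc(C)n1)c1ccc(-c2ccccc2)cc1` differs from compound 3 in a single place: 2-methyl-1,3-thiazol-4-yl in place of 2,5-difluorophenyl on a saturated ring carbon. For the measured compounds named here, no measured pair describes this kind of exchange on the three-membered ring; compounds 1 and 2 carry a plain phenyl there and differ from compound 3 at the amine chain as well, so they offer no clean reference. The change of compound 4 is therefore expected to be of uncertain direction, with a step of a 1.5-fold lower number from compound 3 to compound 4 (0.19 log units; within the scatter) taken only as a central guess and with a wide range on either side. Compound 4 is estimated at 500 nM, between 80 nM and 3000 nM.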

Compound 4, half-maximal effective concentration: 1500 nM
Estimate against measurement, compound 4: 3.0-fold (0.48 log units) below, and the stated range covers the measured number.
By their numbers in this assay, from the lowest: compound 1; then compound 2; then compounds 3 and 4 (each within the scatter of the next).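

Among the compounds shown here, on the three-membered ring, the exchange of 2,5-difluorophenyl for 2-methyl-1,3-thiazol-4-yl gives the first direct reading at this position: in this assay the step is a 1.9-fold higher number from compound 3 to compound 4 (0.29 log units; within the scatter) and so does not separate the two groups on this read-out. With the amine chain shared by compound 3 and compound 4, the saturated ring carbon can thus carry either a six-membered aromatic ring of carbon only or a five-membered aromatic ring with 2 hetero atoms, with 2 hydrogen-bond acceptors entering and 6 heavy atoms in place of 8, and the number stays within the scatter. Nothing measured here accounts for this outcome.

Whether the exchange would read the same way with the 1-aminocyclopentyl chain of compound 1, which carries a plain phenyl on the three-membered ring, stays open, as no pair shown makes this exchange on that chain. Also open, from the compounds shown here alone, is how a pyridine ring, a thiazole without the methyl group or a plain phenyl would read at this ring carbon with the amine chain of compound 3.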